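Swapping a para substituent: from methylsulfanyl to phenoxy

This account rests on a few compounds, and the source may have more. Where it says the series, first, only, none or still open, it means among the compounds named here.

Compound 1 `CC(C)(C)c1ccc(-n2cc(-c3cn([C@H]4C[C@H](O)[C@@H](CO)O4)c(=O)[nH]c3=O)nn2)cc1`: 9000 nM
Compound 2 `O=c1[nH]c(=O)n([C@H]2C[C@H](O)[C@@H](CO)O2)cc1-c1cn(-c2ccc(Cl)cc2)nn1`: 4000 nM
Compound 3 `CSc1ccc(-n2cc(-c3cn([C@H]4C[C@H](O)[C@@H](CO)O4)c(=O)[nH]c3=O)nn2)cc1`: 23000 nM

Three compounds sharing one core, each carrying a different group para to a large group on the outer aromatic ring, have been tested in an ADME assay on HeLa cells (Homo sapiens) for cytotoxicity, read by cell counting, with a stated time of 4 days; on this read-out higher numbers stand for weaker inhibition and lower numbers for stronger inhibition. Compound 3 gives the highest number of the three, that is the weakest inhibition of cell growth: its nearest neighbour is compound 1, and the gap is a 2.6-fold higher number from compound 1 to compound 3 (0.41 log units; beyond the scatter) read in reverse, while against compound 2 the gap is a 5.8-fold higher number from compound 2 to compound 3 (0.76 log units; beyond the scatter).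

For the measured compounds named here, compound 4 `O=c1[nH]c(=O)n([C@H]2C[C@H](O)[C@@H](CO)O2)cc1-c1cn(-c2ccc(Oc3ccccc3)cc2)nn1` keeps the whole core and changes only that para group: phenoxy in place of methylsulfanyl on an aromatic carbon.

Going by the values given here, no measured step involves a phenoxy group, so the only guide is how much this position has moved the number so far. The steps of a 2.3-fold lower number from compound 1 to compound 2 (0.35 log units; beyond the scatter) and a 2.6-fold higher number from compound 1 to compound 3 (0.41 log units; beyond the scatter) are both modest, and even the largest, a 5.8-fold higher number from compound 2 to compound 3 (0.76 log units; beyond the scatter), is still described as modest. A modest shift in this assay is therefore expected for compound 4, most likely towards a lower number, since compound 3 already sits at the top of the measured range.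

Compound 4 is expected to give 10000 nM in this assay, within 3000 nM to 40000 nM, meaning an expected step of a 2.3-fold lower number from compound 3 to compound 4 (0.36 log units; beyond the scatter).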

Compound 4, half-maximal inhibitory concentration: 280 nM
For compound 4 the middle estimate is 36-fold (1.55 log units) above the measured one; the whole stated range lies above it.
By their numbers in this assay, from the lowest: compound 4; then compound 2; then compound 1; then compound 3.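

In this assay, for the compounds shown here, the group para to a large group on the outer ring can move the number much further than the earlier compounds showed: phenoxy gives large steps against methylsulfanyl (an 82-fold lower number from compound 3 to compound 4 (1.91 log units; beyond the scatter)), chloro (a 14-fold lower number from compound 2 to compound 4 (1.15 log units; beyond the scatter)) and tert-butyl (a 32-fold lower number from compound 1 to compound 4 (1.51 log units; beyond the scatter)), whereas the steps among those three groups were all modest. Going by these compounds alone, this makes compound 4 the strongest inhibitor of cell growth of the four, and phenoxy is also the only one of the four groups that brings a six-membered aromatic ring of its own, though that link rests on a single compound. Nothing among the available data explains why the number falls so far.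

The compounds shown cannot separate the part played by the added ring from that of the oxygen joining it to the rest of the molecule, a question that a phenyl group attached directly, a benzyl group or a methoxy group would help to answer. They also leave open whether the outer ring of phenoxy tolerates further groups, such as a chlorine atom or a methoxy group.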